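The source may hold more compounds than are shown below. What is called first, only, known or untested is meant among the compounds shown, and "the series" means these compounds.

Among the measured compounds shown here, in a physicochemical assay for solubility, in phosphate buffer, at pH 7.4 (a higher number here means a more soluble compound, a lower number a less soluble compound), compound 1 `CC(=O)N[C@@H]1CCC[C@H](C(=O)Nc2cc(-c3cnn4c3CC(C)(C)C4)ccn2)C1` gives 970000 nM, and compound 2 `CC(=O)N[C@@H]1CCC[C@H](C(=O)Nc2cc(-c3cnn4c3CC(C)(C)C4)c(C#N)cn2)C1` gives 380000 nM, the lower of the two numbers so far. Compound 3 `CC(=O)N[C@@H]1CCC[C@H](C(=O)Nc2cc(-c3cnn4c3CC(C)(C)C4)c(C)cn2)C1` differs from compound 2 by one change, methyl in place of cyano on an aromatic carbon. For the measured compounds named here, only one measured step bears on this place, a 2.6-fold lower number from compound 1 to compound 2 (0.41 log units; beyond the scatter), a modest drop beyond the usual scatter when cyano replaces hydrogen. Going by the values given here, no measured compound carries methyl here, so this step is only an indirect guide. It does show that compound 1, which has no cyano group, stands higher at 970000 nM. Losing the cyano group may therefore recover part of that drop. The expected change is a 1.4-fold higher number from compound 2 to compound 3 (0.16 log units; within the scatter), a small rise that probably stays within the scatter. For compound 3 the estimated value is 550000 nM, with an expected range from 240000 nM to 1100000 nM.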

Compound 3, solubility: 600000 nM
For compound 3 the middle estimate is 1.1-fold (0.04 log units) below the measured one; the range from low to high includes it.
By their numbers in this assay, from the lowest: compounds 2, 3 and 1 (each within the scatter of the next, the first and the last beyond it).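

In this assay, swapping cyano for methyl gives a 1.6-fold higher number from compound 2 to compound 3 (0.20 log units; within the scatter), and adding methyl in place of hydrogen gives a 1.6-fold lower number from compound 1 to compound 3 (0.21 log units; within the scatter), so at this position methyl cannot be told apart from either neighbouring compound. Only compound 1 and compound 2, with hydrogen and cyano, stand apart beyond the scatter, and methyl overlaps both ends of that small gap. Nothing measured here gives a reason for these numbers.

Still open, from the compounds shown here alone, is whether another group on this aromatic carbon, such as an amine, a methoxy group or a longer alkyl chain, would shift the number beyond the scatter. Also open, going by these compounds, is whether the same small differences among hydrogen, methyl and cyano would hold if another part of the shared core were changed.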